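From 2-chlorophenyl to 3-methylphenyl on an aromatic nitrogen

This account rests on a few compounds, and the source may have more. Where it says the series, first, only, none or still open, it means among the compounds named here.

Measured in a functional assay on MDA-MB-231 cells (Homo sapiens) for inhibition, read by MTT assay, with a stated time of 72 h (on this read-out higher numbers stand for weaker inhibition and lower numbers for stronger inhibition), so far:
compound 1 `Cc1ccc(C(C)C)c(OCc2cn(-c3ccccc3Cl)nn2)c1` gives 26600 nM
compound 2 `Cc1ccc(C(C)C)c(OCc2cn(-c3ccc(F)cc3)nn2)c1` gives 32600 nM

For the measured compounds named here, these are the only two measured compounds. Compound 1 has a single neighbour on the scale, compound 2, and the two stand within the scatter of each other, so neither ranks ahead. Compound 3 `Cc1cccc(-n2cc(COc3cc(C)ccc3C(C)C)nn2)c1` has not yet been measured. It differs from compound 1 by 3-methylphenyl in place of 2-chlorophenyl on an aromatic nitrogen on the shared core, with 3-methylphenyl in place of 2-chlorophenyl on an aromatic nitrogen. Going by the values given here, one measured step bears on this exchange, made at the same place: a 1.2-fold higher number from compound 1 to compound 2 (0.09 log units; within the scatter) with 4-fluorophenyl in place of 2-chlorophenyl. That step stays within the scatter. Among the compounds with values here, it is thin ground, since no measured compound carries 3-methylphenyl. Even so, this second exchange is expected to shift the number by no more than the scatter, in no clear direction. The expected step is a 1.1-fold higher number from compound 1 to compound 3 (0.05 log units; within the scatter) and so remains small. The estimate for compound 3 is 30000 nM with an expected range from 15000 nM to 60000 nM in this measurement.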

Compound 3, half-maximal inhibitory concentration: 31300 nM
Compound 3: middle estimate off by 1.0-fold (0.02 log units), on the low side; the measured number falls inside the stated range.
By their numbers in this assay, from the lowest: compounds 1, 3 and 2 (each within the scatter of the next).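

With 3-methylphenyl, the group on the aromatic nitrogen no longer has to carry a halogen, yet a 1.2-fold higher number from compound 1 to compound 3 (0.07 log units; within the scatter) and a 1.0-fold lower number from compound 2 to compound 3 (0.02 log units; within the scatter) in this assay both stay within the scatter. The earlier pair compared only 2-chlorophenyl with 4-fluorophenyl, whereas the exchange now also covers a group of carbon only, and 2-chlorophenyl, 4-fluorophenyl and 3-methylphenyl cannot be told apart by this read-out on the shared core. The data offer nothing that would account for this sameness among the three compounds.

The compounds shown leave open whether anything at this place can move the number beyond the scatter, for instance an amine or a carboxylic acid on the phenyl ring, or a cyclohexyl ring in place of the phenyl ring. As far as these compounds go, they also say nothing about the isopropyl and methyl groups on the other aromatic ring, which all three compounds share, so the contribution of that part of the molecule to the number remains unknown.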